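One methyl fewer: from compound 3 to compound 4

The compounds below may be only part of what the source reports. "The series", "measured", "known", "first", "only" and "open" are said of these compounds alone.

Measured in a functional assay on SF-295 cells (Homo sapiens); a lower number here means a stronger inhibitor of growth, a higher number a weaker inhibitor of growth:
- compound 1 `COc1cccc(-c2cc(O)c3c(C)cc(C)nc3n2)c1`: 417 nM
- compound 2 `COc1cccc(-c2cc(O)c3cc(C)cnc3n2)c1`: 37.2 nM
- compound 3 `COc1cccc(-c2cc(O)c3c(C)ccnc3n2)c1`: 28.8 nM

Compound 3 has the lowest of the three numbers, but its gap to compound 2 lies within the scatter of repeated measurements. Compound 1 stands well above both.

The next compound is compound 4 `COc1cccc(-c2cc(O)c3cccnc3n2)c1`, which differs from compound 3 by one small edit: hydrogen in place of methyl on an aromatic carbon. This is hydrogen in place of methyl on an aromatic carbon, opposite the ring nitrogen.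

One measured step is of the same kind, a 14-fold lower number from compound 1 to compound 3 (1.16 log units; beyond the scatter), and it is large. However, compound 3 still carries the methyl that leaves now, so that step removed a different methyl and offers only a loose guide. For the measured compounds named here, no measured compound lacks a methyl on the core altogether, so the effect of this edit has not been seen directly.

A large step is therefore not expected, and the expected change is a 1.7-fold higher number from compound 3 to compound 4 (0.24 log units; within the scatter), with a slight lean towards a higher number and no step beyond the scatter as the likeliest outcome. For compound 4 the estimated value is 50 nM, with an expected range from 15 nM to 170 nM.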

Compound 4, concentration for 50% growth inhibition: 52.5 nM
Estimate against measurement, compound 4: 1.1-fold (0.02 log units) below; the range from low to high includes it.
By their numbers in this assay, from the lowest: compounds 3, 2 and 4 (each within the scatter of the next); then compound 1.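

In this assay, removing the methyl opposite the ring nitrogen gives a 1.8-fold higher number from compound 3 to compound 4 (0.26 log units; within the scatter), so hydrogen serves as well as methyl at this position within the scatter. Removing the single methyl of the other singly methylated core gives a 1.4-fold higher number from compound 2 to compound 4 (0.15 log units; within the scatter), also within the scatter, so neither single methyl is needed for growth inhibition on these cores. The earlier step suggested that removing a methyl could matter greatly, but this edit now has a much smaller effect on a different core, and the size of the change depends on which core carries it: the same change on two cores in this assay, a 14-fold lower number (1.16 log units; beyond the scatter) from compound 1 to compound 3 and a 1.4-fold higher number (0.15 log units; within the scatter) from compound 2 to compound 4, 20-fold (1.31 log units) apart, beyond the scatter of two such steps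

The compounds shown carry only hydrogen or methyl at these sites, so it remains open whether a larger or different group, such as ethyl, a chlorine atom, an amine or a carboxylic acid, would be accepted there. Going by these compounds, it also remains open whether the much higher number of compound 1 comes from one particular methyl or from the two methyls being present together.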